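Replacing Carboxymethyl with 4-Cyanophenyl: What Compound 4 Might Show

The source may hold more compounds than are shown below. What is called first, only, known or untested is meant among the compounds shown, and "the series" means these compounds.

Compound 1 `CCOC(=O)c1c(C)nc(-c2ccccc2)n1OC`: in a functional assay on a cell-free system (plasma, Oryctolagus cuniculus) for inhibition, with stated times of 5 min, 1 min and 6 min (a higher number here means a weaker inhibitor, a lower number a stronger inhibitor), compound 1 gives > 30000 nM, which is a limit of the assay.
Compound 2 `CCOC(=O)c1c(C)nc(-c2cccc(C#N)c2)n1OCCC(=O)O`: in this assay compound 2 gives > 30000 nM, again only a limit.
Compound 3 `CCOC(=O)c1c(C)nc(-c2cccc(C#N)c2)n1OCc1ccc(F)cc1`: in this assay compound 3 gives 5880 nM.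

Compound 2 therefore stands at the limit of > 30000 nM in this assay, at which 2 of the 3 values shown sit, with compound 1 sitting there as well. Compound 4 `CCOC(=O)c1c(C)nc(-c2cccc(C#N)c2)n1OCc1ccc(C#N)cc1` differs from compound 2 by 4-cyanophenyl in place of carboxymethyl on a saturated chain carbon bound to an oxygen on an aromatic ring. Among the measured compounds shown here, the only measured step that bears on this is an at least 5.1-fold lower number from compound 2 to compound 3 (0.70 log units; beyond the scatter), where a 4-fluorophenyl entered on a saturated chain carbon bound to an oxygen on an aromatic ring. A similar step, toward a lower number, is expected for compound 4, which is estimated at 6000 nM with a range from 1500 nM to 25000 nM. That estimate for compound 4 means an expected step of an at least 5.0-fold lower number from compound 2 to compound 4 (0.69 log units; beyond the scatter).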

Compound 4, half-maximal inhibitory concentration: 4240 nM
Compound 4: middle estimate off by 1.4-fold (0.15 log units), on the high side; the range from low to high includes it.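

With 4-cyanophenyl in place of carboxymethyl on this saturated chain carbon, this assay shows an at least 7.0-fold lower number from compound 2 to compound 4 (0.84 log units; beyond the scatter), so the lower number seen with compound 3 is not confined to its 4-fluorophenyl. Cyano in place of fluoro on an aromatic carbon gives a 1.4-fold lower number from compound 3 to compound 4 (0.14 log units; within the scatter), so the two groups cannot be told apart at this position. The first step remains only a bound, with compound 2 at a limit: the limit of > 30000 nM in this assay, at which 2 of the 4 values shown sit.

Still open, going by these compounds, is whether an unsubstituted phenyl would serve equally well here. On these data alone, whether a longer alkyl chain or an amine could replace the aromatic ring also remains open.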